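A triazole-bearing analogue gains a trifluoromethyl group

A few compounds are considered here, and "the series" means these few. Any claim that something is new, unique, unknown or untested is made for them only; others in the source may bear on it.

Compound 1 `CCC(C)(C)Cc1c[nH]c(CCc2ccc(-c3ccccc3O)cc2)n1` is the reference point here: in a functional assay for agonist activity at Bombesin receptor subtype-3 (Mus musculus) (a lower number here means that less compound is needed, a higher number that more compound is needed for the effect), compound 1 gives 34 nM. Compound 2 `CCC(C)(C)Cc1c[nH]c(CCc2ccc(-c3ccccc3OCc3ncn[nH]3)cc2)n1` carries the same core but adds a (1H-1,2,4-triazol-5-yl)methoxy group in place of the free hydroxyl. In this assay compound 2 is recorded as "not determined" (no result reported), so no single number marks where compound 2 stands, and nothing can be said about how the triazole changed the potency relative to compound 1.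

Compound 3 `CCC(C)(C)Cc1c[nH]c(CCc2ccc(-c3ccccc3OCc3nc(C(F)(F)F)n[nH]3)cc2)n1` is the next step. It differs from compound 2 by trifluoromethyl in place of hydrogen on an aromatic carbon of the triazole. Among the measured compounds shown here, no measured pair in this set shows what such an exchange does, so the size of the step in this assay cannot be read from the data. The expectation is therefore a shift no larger than the usual scatter, in either direction, anchored loosely on the value of compound 1.

For compound 3 the estimated result in this assay is 35 nM, expected to fall between 8 nM and 150 nM.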

Compound 3, half-maximal effective concentration: 12 nM
Estimate against measurement, compound 3: 2.9-fold (0.46 log units) above; the measured number falls inside the stated range.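

The oxygen on the aromatic ring of compound 1 turns out to accept a large substituent: in this assay, putting (3-(trifluoromethyl)-1H-1,2,4-triazol-5-yl)methyl in place of the hydrogen on that oxygen gives a 2.8-fold lower number from compound 1 to compound 3 (0.45 log units; beyond the scatter), a modest change that lies beyond the scatter. Among the compounds shown here, the free hydroxyl is therefore not required for activity here, at least with this substituent, which the earlier compounds could not show. Compound 2 has no reported number, so the steps involving it cannot be read and the share of the trifluoromethyl in this gain stays unknown, while nothing measured here accounts for the gain itself.

The compounds shown leave open whether the aromatic carbon of the triazole would serve equally well with a methyl, a chlorine or an amine in place of trifluoromethyl. They also leave open how a simple methyl on the oxygen, a carboxylic acid in place of the triazole, or a longer chain linking the triazole to the oxygen would compare in this assay.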